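Dropping One Methoxy: From Compound 2 to Compound 3

The source may hold more compounds than are shown below. What is called first, only, known or untested is meant among the compounds shown, and "the series" means these compounds.

In a functional assay on PANC-1 cells (Homo sapiens) for cytotoxicity, read by MTT assay, with a stated time of 72 h (on this read-out lower numbers stand for stronger inhibition and higher numbers for weaker inhibition), compound 1 `O=C1C(Nc2ccc(-c3ccc(F)cc3)cc2)=CC(=O)c2ncncc21` gives 3200 nM. Compound 2 `COc1ccc(NC2=CC(=O)c3ncncc3C2=O)cc1OC` holds the lowest of the two numbers, and in this assay compound 2 gives 900 nM, a step beyond the scatter from compound 1. Compound 3 `COc1ccc(NC2=CC(=O)c3ncncc3C2=O)cc1` has not been measured; it differs from compound 2 by hydrogen in place of methoxy on an aromatic carbon. Within the data shown here, no measured pair shows a step of this kind, so the expectation rests on the change alone. Compound 3 is expected to show a step of a 1.7-fold higher number from compound 2 to compound 3 (0.22 log units; within the scatter) of modest size, likely toward a weaker number, possibly not beyond the scatter. The estimate for compound 3 is 1500 nM, spanning 500 nM to 4500 nM.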

Compound 3, half-maximal inhibitory concentration: 800 nM
Estimate against measurement, compound 3: 1.9-fold (0.27 log units) above; low and high end bracket the measured number.
By their numbers in this assay, from the lowest: compounds 3 and 2 (each within the scatter of the next); then compound 1.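

With a 1.1-fold lower number from compound 2 to compound 3 (0.05 log units; within the scatter) in this assay, hydrogen in place of methoxy on this aromatic carbon, ortho to a methoxy group, gives no step beyond the scatter, so this methoxy is not required for the read-out. Methoxy in place of 4-fluorophenyl gives a 4.0-fold lower number from compound 1 to compound 3 (0.60 log units; beyond the scatter), a single-place step beyond the scatter. Nothing available explains either step. As far as these compounds go, whether an amine or a chlorine atom on this carbon would shift the number remains open, as does the effect of replacing the remaining methoxy with hydrogen.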